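The source may hold more compounds than are shown below. What is called first, only, known or untested is meant among the compounds shown, and "the series" means these compounds.

Measured compounds:
compound 1, `Oc1ccc(-c2cc(-c3ccc(O)cc3)nc(-c3ccc(O)cc3)c2)cc1`, gives 3160 nM
compound 2, `Oc1ccc(-c2cc(-c3ccc(O)cc3)nc(-c3cccc(O)c3)c2)cc1`, gives 5800 nM
compound 3, `Oc1ccc(-c2cc(-c3cccc(O)c3)nc(-c3ccccc3O)c2)cc1`, gives 3420 nM

All three numbers come from a functional assay on DU-145 cells (Homo sapiens) for cytotoxicity, read by CCK-8 assay, with a stated time of 4 days; on this read-out lower numbers stand for stronger inhibition and higher numbers for weaker inhibition. Compound 2 and compound 3 differ in their cores by 2-hydroxyphenyl in place of 4-hydroxyphenyl on an aromatic carbon, a change that gives a 1.7-fold lower number from compound 2 to compound 3 (0.23 log units; within the scatter). The change 4-hydroxyphenyl in place of 3-hydroxyphenyl on an aromatic carbon gives a 1.8-fold lower number from compound 2 to compound 1 (0.26 log units; within the scatter). Compound 4, `Oc1ccc(-c2cc(-c3ccc(O)cc3)nc(-c3ccccc3O)c2)cc1`, is not yet measured in this assay and arises from compound 3 by 4-hydroxyphenyl in place of 3-hydroxyphenyl on an aromatic carbon. The surroundings are not identical: for compound 2 to compound 1 the site is meta to two 4-hydroxyphenyl groups, while for compound 3 to compound 4 it is meta to a 2-hydroxyphenyl group and meta to a 4-hydroxyphenyl group, so this is the same kind of change, not the same one. Going by the values given here, the expected step in this assay is a 1.4-fold lower number from compound 3 to compound 4 (0.14 log units; within the scatter), placed beside a 1.8-fold lower number from compound 2 to compound 1 (0.26 log units; within the scatter), and it rests on compound 3 at 3420 nM with the earlier step as the only precedent, since all three measured values lie within the usual scatter of one another. Compound 4 is therefore estimated at 2500 nM, with a likely range from 1200 nM to 5500 nM.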

Compound 4, half-maximal inhibitory concentration: > 50000 nM
Compound 4 ended at the assay's limit; the forecaster's own chance of this, stated with the estimate: 5%; middle value at least 20-fold (1.30 log units) from the limit.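

In this assay compound 4 gives > 50000 nM, which is a limit of the assay and not a number. The steps into it are therefore bounds, an at least 14-fold higher number from compound 3 to compound 4 (1.16 log units; beyond the scatter), an at least 8.6-fold higher number from compound 2 to compound 4 (0.93 log units; beyond the scatter) and an at least 15-fold higher number from compound 1 to compound 4 (1.19 log units; beyond the scatter), and 4-hydroxyphenyl in place of 3-hydroxyphenyl does not carry over unchanged from one core to the other: the same change on two cores in this assay, a 1.8-fold lower number (0.26 log units; within the scatter) from compound 2 to compound 1 and an at least 14-fold higher number (1.16 log units; beyond the scatter) from compound 3 to compound 4, at least 26-fold (1.42 log units) apart, beyond the scatter of two such steps. The same holds for 2-hydroxyphenyl in place of 4-hydroxyphenyl, although one pair of steps for each change shows only that the outcome depends on the core, not the true size of the gap or what sets it: the same change on two cores in this assay, a 1.7-fold lower number (0.23 log units; within the scatter) from compound 2 to compound 3 and an at least 15-fold higher number (1.19 log units; beyond the scatter) from compound 1 to compound 4, at least 26-fold (1.42 log units) apart, beyond the scatter of two such steps.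

As far as these compounds go, it remains open whether the large step is confined to cores that carry a 2-hydroxyphenyl group, as only compound 3 and compound 4 bear on that question. Also open, from the compounds shown here alone, is how a methoxy group or an amine in place of a hydroxyl group would behave on the shared core.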